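A few compounds are considered here, and "the series" means these few. Any claim that something is new, unique, unknown or untested is made for them only; others in the source may bear on it.

In a functional assay on HeLa cells (Homo sapiens) for cytotoxicity, read by MTT assay (on this read-out lower numbers stand for stronger inhibition and higher numbers for weaker inhibition), compound 1 `CCCCCCCCCC(O)CN` gives 4360 nM. Compound 2 `NCC(O)CCCCCCCCC(=O)O` carries a carboxy group; in this assay compound 2 is recorded as "not active" (no number reported), so it stands with no single number and cannot be placed against compound 1 on a scale. Compound 3 `NCC(O)CCCCCCCCCO` differs from compound 2 by hydroxymethyl in place of carboxy on a saturated chain carbon, nine bonds along the chain from an oxygen on a saturated carbon. For the measured compounds named here, no step between measured compounds covers this change; the expected direction in this assay is toward measurable inhibition, with the size of the step left open since compound 2 has no number. Compound 3 is estimated at 20000 nM, with a range from 5000 nM to 80000 nM, and a limit rather than a number remains a real possibility.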

Compound 3, half-maximal inhibitory concentration: 8790 nM
For compound 3 the middle estimate is 2.3-fold (0.36 log units) above the measured one, within the range that was stated.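

Hydroxy in place of hydrogen on a saturated chain carbon gives a 2.0-fold higher number from compound 1 to compound 3 (0.30 log units; within the scatter) in this assay. With hydroxymethyl in place of carboxy, compound 3 has a number where compound 2 is recorded as not active, so that step cannot be read as a size. No measurement shown here bears on the reason for this result. The compounds shown leave open whether an amine or a methyl ester at this position gives a number, and whether a longer chain ending in hydroxy does.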